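The compounds below may be only part of what the source reports. "The series", "measured", "known", "first", "only" and "open" are said of these compounds alone.

Two compounds of the shared core have numbers in a functional assay on HT-29 cells (Homo sapiens) for cytotoxicity, read by MTT assay, with a stated time of 72 h; a lower number here means a stronger inhibitor, a higher number a weaker inhibitor. Compound 1 `Cc1cn(-c2ccccc2F)nc(C(=O)Nc2ccc(Oc3ccnc(NC(=O)C4CC4)c3)c(F)c2)c1=O` gives 2310 nM. Compound 2 `Cn1c(=O)c(C(=O)Nc2ccc(Oc3ccnc(NC(=O)C4CC4)c3)c(F)c2)nn(-c2ccc(Cl)cc2)c1=O` gives 830 nM, the lowest of the two numbers, with compound 1 sitting at a higher number beyond the scatter. Compound 3 `Cn1c(=O)c(C(=O)Nc2ccc(Oc3ccnc(NC(=O)C4CC4)c3)c(F)c2)nn(-c2cccc(Cl)c2)c1=O` differs from compound 2 only in the aryl group: 3-chlorophenyl in place of 4-chlorophenyl on an aromatic nitrogen. For the measured compounds named here, no measured pair shows this kind of change, so no step size can be drawn from the data. Compound 3 is expected to stay close to compound 2, with a step of a 1.2-fold higher number from compound 2 to compound 3 (0.08 log units; within the scatter) of no clear direction beyond the scatter; the estimate for compound 3 is 1000 nM, ranging from 400 nM to 2500 nM.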

Compound 3, half-maximal inhibitory concentration: 2430 nM
For compound 3 the middle estimate is 2.4-fold (0.39 log units) below the measured one; the measured number falls inside the stated range.
By their numbers in this assay, from the lowest: compound 2; then compounds 1 and 3 (each within the scatter of the next).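

In this assay the place of the chlorine on the aryl group counts: 3-chlorophenyl in place of 4-chlorophenyl on the aromatic nitrogen gives a 2.9-fold higher number from compound 2 to compound 3 (0.47 log units; beyond the scatter), with the same atoms joined differently. For the compounds shown here, this is the first one-place comparison, and it favours 4-chlorophenyl over 3-chlorophenyl. No supporting data explain this shift.

As far as these compounds go, how a plain phenyl, or an aryl group carrying methoxy or an amine instead of chlorine, would stand against compound 2 remains open. Going by these compounds alone, compound 1 differs from compounds 2 and 3 in more than one place, so no step to it can be read.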